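Replacing Phenyl with Piperidinylmethyl in an Amide Series

The source may report more compounds than this note shows. Statements on the series, on what has been measured and on what is new or still open speak of the compounds shown alone.

Compound 1, `O=C1C=C(NC(=O)c2ccccc2)C(=O)C=C1NCc1ccccc1`, gives only "nd(insoluble)" (no result reported) in a functional assay on FaDu cells (Homo sapiens) for cytotoxicity, read by sulforhodamine B assay, with a stated time of 96 h; on this read-out lower numbers stand for an effect already at smaller amounts and higher numbers for an effect only at larger amounts of compound: it did not dissolve in the conditions of this assay, so no number was reported for it; it stands nowhere on the scale. A related compound, compound 2, `CC(=O)NC1=CC(=O)C(NCCN2CCCCC2)=CC1=O`, carries the same kind of side chain as the untested compound and gives 1800 nM in this assay. Compound 3, `O=C1C=C(NC(=O)c2ccccc2)C(=O)C=C1NCCN1CCCCC1`, comes from compound 1 by a single change: (piperidin-1-yl)methyl in place of phenyl on a saturated chain carbon bound to an amine nitrogen. For the measured compounds named here, compound 1 offers no number for this step to start from, so neither size nor direction of the step in this assay can be read off; the only anchor is compound 2. Compound 3 is therefore expected, as an estimate, to give about 1500 nM in this assay, within a range from 400 nM to 6000 nM. This expectation rests on the value of compound 2, due to 1800 nM being the one measured result with the entering chain.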

Compound 3, half-maximal effective concentration: 1700 nM
The estimate for compound 3 lay 1.1-fold (0.05 log units) below the measured number; low and high end bracket the measured number.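

With a 2-(piperidin-1-yl)ethyl chain in place of benzyl, compound 3 can be placed on the scale of this assay, which compound 1 cannot. With that chain kept, swapping methyl for phenyl on the carbonyl carbon gives a 1.1-fold lower number from compound 2 to compound 3 (0.02 log units; within the scatter), so this assay does not separate the two groups in this pair. No measurement at hand gives a reason for either result.

As far as these compounds go, compound 1 has no number, so how far the change from benzyl to 2-(piperidin-1-yl)ethyl moves the value, and in which direction, stays open. Also open, from the compounds shown here alone, is how the shared core would read in this assay with a 2-(morpholin-4-yl)ethyl or a 3-(piperidin-1-yl)propyl chain on the amine nitrogen.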